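This account rests on a few compounds, and the source may have more. Where it says the series, first, only, none or still open, it means among the compounds named here.

Compound 1 `Cc1ccccc1-c1n[nH]c(-c2ccccc2)n1` opens the series; in a functional assay on the whole organism (Cricetulus griseus) with Cricetinae gen. sp. as the target (a lower number here means that less compound is needed, a higher number that more compound is needed for the effect), compound 1 gives 10 mg/kg. Compound 2 `CCc1ccccc1-c1n[nH]c(-c2ccccc2)n1` carries the change (methyl in place of hydrogen on a saturated chain carbon bound to an aromatic carbon), and in this assay compound 2 gives 5 mg/kg, a step of a 2.0-fold lower number from compound 1 to compound 2 (0.30 log units; within the scatter). Compound 3 `CCOc1cccc(-c2n[nH]c(-c3ccccc3C)n2)c1` stands on a different core, and the difference between the two cores is not broken down here. In this assay compound 3 gives 5 mg/kg, the same number at the digits read as compound 2. Compound 4 `CCOc1cccc(-c2n[nH]c(-c3ccccc3CC)n2)c1` is not yet measured; it differs from compound 3 by methyl in place of hydrogen on a saturated chain carbon bound to an aromatic carbon, the same change as that made from compound 1 to compound 2. Because that change once gave a 2.0-fold lower number from compound 1 to compound 2 (0.30 log units; within the scatter), an expected step of a 1.4-fold lower number from compound 3 to compound 4 (0.15 log units; within the scatter) is set beside it. Compound 4 is thus estimated at 3.5 mg/kg, expected to fall between 1.5 mg/kg and 8 mg/kg.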

Compound 4, dose for half-maximal effect: 4 mg/kg
Compound 4: middle estimate off by 1.1-fold (0.06 log units), on the low side; the measured number falls inside the stated range.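

In this assay, methyl in place of hydrogen on a saturated chain carbon bound to an aromatic carbon gives a 1.3-fold lower number from compound 3 to compound 4 (0.10 log units; within the scatter) on the core of compound 3. Set beside the earlier step, the two readings do not differ: the same change on two cores in this assay, a 2.0-fold lower number (0.30 log units; within the scatter) from compound 1 to compound 2 and a 1.3-fold lower number (0.10 log units; within the scatter) from compound 3 to compound 4, 1.6-fold (0.20 log units) apart, within the scatter of two such steps. The change thus carries from one core to the other with no difference that can be told apart, but each step lies within the scatter, so neither shows that the change itself moves the number, and two cores establish no general rule.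

The compounds shown leave open whether a longer chain such as propyl, or an amine or a carboxylic acid, at this place would give a step beyond the scatter. They also leave open how the change behaves on any other core.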